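Shortening the acid chain in the naphthonitrile series

This account rests on a few compounds, and the source may have more. Where it says the series, first, only, none or still open, it means among the compounds named here.

Compound 2 `N#Cc1ccc(Nc2cnccc2SCCCCCC(=O)O)c2ccccc12` gives 4240 nM in an assay on HEK293 cells for inhibition of solute carrier family 22 member 12 (Homo sapiens), read by scintillation counting, with stated times of 30 min and 15 min; a higher number here means a weaker inhibitor, a lower number a stronger inhibitor. For the measured compounds named here, of the two numbers in hand this is the larger, but the only other compound, compound 1 `N#Cc1ccc(Nc2cnccc2SCCCC(=O)O)c2ccccc12` with 2780 nM, sits within the scatter of it, so the two are not told apart. Going by the values given here, the single step recorded so far, 2-carboxyethyl in place of carboxy on a saturated chain carbon three bonds along the chain from a sulfur, reads a 1.5-fold higher number from compound 1 to compound 2 (0.18 log units; within the scatter).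

Compound 3 `N#Cc1ccc(Nc2cnccc2SCCCCC(=O)O)c2ccccc12` has not yet been measured in this assay. It differs from compound 2 as follows: carboxy in place of carboxymethyl on a saturated chain carbon, four bonds along the chain from a sulfur. The acid chain thus becomes shorter than in compound 2 and longer than in compound 1. Among the compounds with values here, the one step that bears on this change, a 1.5-fold higher number from compound 1 to compound 2 (0.18 log units; within the scatter), lengthened the same chain and stayed within the scatter, so a shortening of it is expected to give a 1.2-fold lower number from compound 2 to compound 3 (0.10 log units; within the scatter) in this assay, with no movement beyond the scatter in either direction. Compound 3 is therefore estimated at 3400 nM, within a range from 1700 nM to 7000 nM.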

Compound 3, half-maximal inhibitory concentration: 2280 nM
Compound 3: middle estimate off by 1.5-fold (0.17 log units), on the high side; low and high end bracket the measured number.
By their numbers in this assay, from the lowest: compounds 3, 1 and 2 (each within the scatter of the next).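

Read in this assay, the shortening at this place, on a saturated chain carbon, four bonds along the chain from a sulfur, gives a 1.9-fold lower number from compound 2 to compound 3 (0.27 log units; within the scatter) while the comparison with the shorter chain gives a 1.2-fold lower number from compound 1 to compound 3 (0.09 log units; within the scatter) and so neither new step separates compound 3 from its neighbours. With the earlier step, all three chain lengths in the series now lie within the scatter of one another, so the change from carboxymethyl to carboxy has no resolved effect here, and no preferred length can be named among compounds 1, 2 and 3. No accompanying measurement offers an explanation for these numbers.

The compounds shown leave open whether a chain shorter than that of compound 1 or longer than that of compound 2 would produce a step beyond the scatter. They also leave open how a branched chain, or a tetrazole, primary amide or methyl ester in place of the carboxylic acid, would read in this assay on the same core.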